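Growing the Ether Side Chain: From Compound 2 to Compound 4

A few compounds are considered here, and "the series" means these few. Any claim that something is new, unique, unknown or untested is made for them only; others in the source may bear on it.

Compound 1 `COCc1cc2cc(/C(=N\O)Nc3cccc(F)c3)ccc2o1`: 6100 nM
Compound 2 `COCc1cc2cc(/C(=N\O)Nc3cccc(Cl)c3)ccc2o1`: 2200 nM
Compound 3 `COCc1cc2cc(/C(=N\O)Nc3cccc(Br)c3)ccc2o1`: 2500 nM

All three compounds were tested in an assay on tissue (HeLa cells) for inhibition of Indoleamine 2,3-dioxygenase 1 (Homo sapiens), read by spectrophotometry; a lower number here means a stronger inhibitor, a higher number a weaker inhibitor. Compound 2 has the lowest of the three numbers. The gap to compound 3, a 1.1-fold higher number from compound 2 to compound 3 (0.06 log units; within the scatter), is within the scatter, so these two cannot be told apart. The gap to compound 1 is larger: a 2.8-fold lower number from compound 1 to compound 2 (0.44 log units; beyond the scatter), and likewise a 2.4-fold lower number from compound 1 to compound 3 (0.39 log units; beyond the scatter), both beyond the scatter.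

Compound 4 `O/N=C(/Nc1cccc(Cl)c1)c1ccc2oc(COCC3CC3)cc2c1` differs from compound 2 in one place: cyclopropyl in place of hydrogen on a saturated chain carbon bound to an oxygen on a saturated carbon. Going by the values given here, none of the measured steps bear on this change. All three of them swap a halogen on an aromatic carbon and leave the methoxymethyl chain untouched, so nothing in the measured set tells how lengthening that chain affects this assay. Without a guide, the fairest expectation is no step beyond the scatter, with a wide range to allow for surprise in either direction. Compound 4 is therefore expected to come in near 2000 nM, within 600 nM to 7000 nM, which means an expected step of a 1.1-fold lower number from compound 2 to compound 4 (0.04 log units; within the scatter).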

Compound 4, half-maximal inhibitory concentration: 17600 nM
Beside the measured number, compound 4's estimate is 8.8-fold (0.94 log units) below it; the measured number lies above the stated range.
By their numbers in this assay, from the lowest: compounds 2 and 3 (each within the scatter of the next); then compound 1; then compound 4.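

Going from methoxymethyl to (cyclopropylmethoxy)methyl while the chloro group stays in place gives an 8.0-fold higher number from compound 2 to compound 4 (0.90 log units; beyond the scatter) in this assay. Going by these compounds alone, this is the first reading on the ether side chain, which the halogen swaps left untouched, and it shows that the assay responds to a change there, with the added cyclopropyl going along with a weaker inhibitor. No measurement shown here bears on why the number rises.

Still open, from the compounds shown here alone, is whether this step belongs to cyclopropyl itself or would come with any growth of the chain, a question that a plain ethoxymethyl chain, a longer straight chain or a hydroxymethyl group could help settle. Also open, going by these compounds, is whether a group such as an amine at the end of this chain would move the number in the other direction.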